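Replacing methoxy with (3,5-difluorobenzyl)carbamoyl on compound 1

The source may hold more compounds than are shown below. What is called first, only, known or untested is meant among the compounds shown, and "the series" means these compounds.

Measured in a functional assay on EBC-1 cells (Homo sapiens) for antiproliferative activity, with a stated time of 72 h; a lower number here means a stronger inhibitor, a higher number a weaker inhibitor:
- compound 1 `COc1ccc(-c2cc(F)c3ncc(Cc4ccc5ncccc5c4)n3c2)cc1F` gives 407 nM
- compound 2 `CNC(=O)c1cccc(-c2cc(F)c3ncc(Cc4ccc5ncccc5c4)n3c2)c1` gives 400 nM

Compound 1 and compound 2 cannot be told apart on these numbers (a 1.0-fold lower number from compound 1 to compound 2 (0.01 log units; within the scatter)). Compound 3 `O=C(NCc1cc(F)cc(F)c1)c1ccc(-c2cc(F)c3ncc(Cc4ccc5ncccc5c4)n3c2)cc1F` keeps the core of compound 1 but carries (3,5-difluorobenzyl)carbamoyl in place of methoxy on an aromatic carbon, ortho to a fluoro group ((3,5-difluorobenzyl)carbamoyl in place of methoxy on an aromatic carbon). Within the data shown here, only one measured step bears on this. It replaced 3-fluoro-4-methoxyphenyl with 3-(methylcarbamoyl)phenyl, which also brought in an amide, and the number for compound 2 stayed within the scatter (a 1.0-fold lower number from compound 1 to compound 2 (0.01 log units; within the scatter)). Among the measured compounds shown here, no measured compound carries the new, much larger group, so the data give no direction. A change no larger than the scatter is therefore expected (a 1.2-fold lower number from compound 1 to compound 3 (0.07 log units; within the scatter)). The estimated value for compound 3 is 350 nM (expected range 100 nM to 1200 nM).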

Compound 3, half-maximal inhibitory concentration: 53.6 nM
For compound 3 the middle estimate is 6.5-fold (0.81 log units) above the measured one; the measured number lies below the stated range.
By their numbers in this assay, from the lowest: compound 3; then compounds 2 and 1 (each within the scatter of the next).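

In this assay, this position on the aromatic ring, ortho to a fluoro group, tolerates a much larger group than methoxy: placing (3,5-difluorobenzyl)carbamoyl there gives a 7.6-fold lower number from compound 1 to compound 3 (0.88 log units; beyond the scatter). Among these compounds, the earlier change gave only a 1.0-fold lower number from compound 1 to compound 2 (0.01 log units; within the scatter), so this is the first step here to move the number beyond the scatter. Nothing available explains the gain.

The new group brings an amide and a fluorinated aromatic ring together, so these compounds cannot show which part matters, or whether both are needed. A plain benzyl amide without the two fluorines, or a carboxylic acid at the same position, would help to separate these parts.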